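The compounds below may be only part of what the source reports. "The series", "measured", "known", "first", "only" and "open" are said of these compounds alone.

In a functional assay on DU-145 cells (Homo sapiens) for inhibition, read by trypan blue exclusion, with a stated time of 96 h (on this read-out lower numbers stand for stronger inhibition of growth and higher numbers for weaker inhibition of growth), compound 1 `O=C(/C(=C\c1ccc([N+](=O)[O-])c(O)c1)SCc1ccc(Br)cc1)c1ccc([N+](=O)[O-])cc1` gives 1000 nM, compound 2 `O=C(O)c1ccc(C(=O)/C(=C\c2ccc([N+](=O)[O-])c(O)c2)SCc2ccc(Br)cc2)cc1` gives 10000 nM and compound 3 `O=C(/C(=C\c1ccc([N+](=O)[O-])c(O)c1)SCc1ccc(Br)cc1)c1cc(Cl)ccc1O` gives 10000 nM. Compound 2 thus stands level with compound 3, and together they hold the highest number of the three, which means weaker inhibition of growth than compound 1 shows.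

Compound 4 `O=C(O)c1ccc(C(=O)/C(=C\c2ccc(Br)cc2)SCc2ccc(Br)cc2)cc1` differs from compound 2 by having 4-bromophenyl in place of 3-hydroxy-4-nitrophenyl on a double-bonded chain carbon bound to a double-bonded chain carbon.

Among the compounds with values here, no measured step touches this group. All three steps concern the other aromatic group, the one tied to the carbonyl carbon. Carboxy in place of nitro gave a 10-fold higher number from compound 1 to compound 2 (1.00 log units; beyond the scatter), and 5-chloro-2-hydroxyphenyl in place of 4-nitrophenyl gave a 10-fold higher number from compound 1 to compound 3 (1.00 log units; beyond the scatter), while the swap between the two weaker compounds gave no change at the digits printed from compound 2 to compound 3 (within the scatter). These steps show how far a single change can move the number in this small set, but not which way the new change will go.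

The expectation therefore rests on compound 2 at 10000 nM, with no shift beyond the scatter expected in this assay, though with wide uncertainty. The expected outcome is no change at the digits printed from compound 2 to compound 4 (within the scatter). For compound 4 the estimate is 10000 nM, with an expected range from 3000 nM to 30000 nM.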

Compound 4, concentration for 50% growth inhibition: 1000 nM
Compound 4: the middle estimate sits 10-fold (1.00 log units) above what was measured, outside the stated range (below it).
By their numbers in this assay, from the lowest: compounds 1 and 4 (each within the scatter of the next); then compounds 2 and 3 (each within the scatter of the next).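

In this assay, the group on a double-bonded chain carbon bound to a double-bonded chain carbon can also move the number: 4-bromophenyl in place of 3-hydroxy-4-nitrophenyl gives a 10-fold lower number from compound 2 to compound 4 (1.00 log units; beyond the scatter). Within the data shown here, the earlier steps all changed the aromatic group on the carbonyl carbon, so this is the first sign that the other aromatic group counts as well, and here the change brings stronger inhibition of growth with the carboxy group kept in place. Nothing available explains why this swap has this effect.

The swap removes the hydroxy and nitro groups and brings in bromine all at once, so the compounds shown cannot tell which of these carries the step. From the compounds shown here alone, whether a plain phenyl or a 4-aminophenyl at this place would behave the same remains open, as does whether 4-bromophenyl would have a similar effect with 4-nitrophenyl on the carbonyl carbon.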